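A few compounds are considered here, and "the series" means these few. Any claim that something is new, unique, unknown or untested is made for them only; others in the source may bear on it.

Compound 1 `CC(C)(C)OC(=O)N[C@@H](CC(=O)OC1CCCC1)C(=O)OCc1ccc(Cl)cc1`: in a functional assay on IMR-32 cells for inhibition of Voltage-dependent N-type calcium channel subunit alpha-1B (Homo sapiens), read by calcium flux (on this read-out higher numbers stand for weaker inhibition and lower numbers for stronger inhibition), compound 1 gives 3300 nM.
Compound 2 `COc1ccc(CNC(=O)[C@H](CSCC2CCCCC2)NC(=O)OC(C)(C)C)cc1`: in this assay compound 2 gives 610 nM.
Compound 3 `CC(C)(C)OC(=O)N[C@@H](CC(=O)OC1CCCC1)C(=O)OCc1ccc(Br)cc1`: in this assay compound 3 gives 3400 nM.

Compound 3 has the highest of these three numbers. The step of a 1.0-fold higher number from compound 1 to compound 3 (0.01 log units; within the scatter) lies within the scatter, so those two cannot be told apart, while compound 2, of different build, has a clearly lower number. Compound 4 `COc1cccc(COC(=O)[C@H](CC(=O)OC2CCCC2)NC(=O)OC(C)(C)C)c1` differs from compound 3 by 3-methoxyphenyl in place of 4-bromophenyl on a saturated chain carbon bound to an oxygen next to a carbonyl group. For the measured compounds named here, no measured step covers this change: the only measured step, a 1.0-fold higher number from compound 1 to compound 3 (0.01 log units; within the scatter), swaps one halogen for another at the same place and stays within the scatter. With nothing pointing either way, compound 4 is expected to show a 1.1-fold lower number from compound 3 to compound 4 (0.05 log units; within the scatter), a step not beyond the scatter. The estimate for compound 4 in this assay is 3000 nM, within 1200 nM to 8000 nM.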

Compound 4, half-maximal inhibitory concentration: 3800 nM
The estimate for compound 4 lay 1.3-fold (0.10 log units) below the measured number; the range from low to high includes it.
By their numbers in this assay, from the lowest: compound 2; then compounds 1, 3 and 4 (each within the scatter of the next).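

Swapping 4-bromophenyl for 3-methoxyphenyl is a larger change than the earlier swap of one halogen for another, yet in this assay it gives a 1.1-fold higher number from compound 3 to compound 4 (0.05 log units; within the scatter) and, against the chloro compound, a 1.2-fold higher number from compound 1 to compound 4 (0.06 log units; within the scatter) and both steps stay within the scatter. So at this place on the shared core, the ring can carry a different group under a different name without a readable shift in the number. Nothing available explains this lack of change. Still open, from the compounds shown here alone, is whether an amine or a carboxylic acid on this ring would move the number. Also open, going by these compounds, is what a plain alkyl chain in place of the ring would do.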